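Nitro in place of methyl: working notes on compound 4

The source may hold more compounds than are shown below. What is called first, only, known or untested is meant among the compounds shown, and "the series" means these compounds.

Measured so far in this series:
compound 1 `COc1ccc(/C=N/NC(=O)c2cc([N+](=O)[O-])cc([N+](=O)[O-])c2)cc1` gives 3.08
compound 2 `Cc1ccc(C(=O)N/N=C/c2cccc([N+](=O)[O-])c2)cc1` gives 3.85
compound 3 `O=C(N/N=C/c1cccc([N+](=O)[O-])c1)c1ccccc1Br` gives 4.17

In a physicochemical assay for lipophilicity (on this read-out lower numbers stand for lower lipophilicity and higher numbers for higher lipophilicity), compound 2 stands second highest of the three. Its nearest neighbour is compound 3, reached by a number 0.32 log units higher from compound 2 to compound 3 (beyond the scatter); its furthest is compound 1, whose number lies clearly lower.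

Compound 4 `O=C(N/N=C/c1cccc([N+](=O)[O-])c1)c1ccc([N+](=O)[O-])cc1` carries nitro in place of methyl on an aromatic carbon. Going by the values given here, no measured step exchanges a methyl for a nitro. Among the compounds with values here, the one step in hand, a number 0.32 log units higher from compound 2 to compound 3 (beyond the scatter), swaps one aryl for another on the carbonyl carbon and does not bear on this change. Compound 1, bearing nitro groups and a methoxy, shows the lowest value of the three, but it differs from compound 2 in more than one place, so it gives only a loose hint. A downward step is nevertheless expected, estimated at a number 0.55 log units lower from compound 2 to compound 4 (beyond the scatter). Compound 4 is thus expected near 3.3, with a range from 2.9 to 3.7.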

Compound 4, partition coefficient: 3.33
For compound 4 the middle estimate is 0.03 log units below the measured one; the measured number falls inside the stated range.
By their numbers in this assay, from the lowest: compounds 1 and 4 (each within the scatter of the next); then compound 2; then compound 3.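

In this assay, going by these compounds alone, nitro in place of methyl on an aromatic carbon, para to a large group, gives a number 0.52 log units lower from compound 2 to compound 4 (beyond the scatter) as the first single-place reading of this change. Together with a number 0.32 log units higher from compound 2 to compound 3 (beyond the scatter) as the other step from compound 2, it shows that exchanges on this aryl can move the number in either direction. The data in hand offer no explanation for the shift.

From the compounds shown here alone, whether an amine or a carboxylic acid at this same place would also lower the number remains open. So does whether the nitro step would carry over to the core of compound 1.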